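Moving a chlorine around the ring: compound 4

The source may hold more compounds than are shown below. What is called first, only, known or untested is meant among the compounds shown, and "the series" means these compounds.

Three compounds share a core carrying a hydroxyphenyl group, a chlorophenyl group and a third small ring. Compound 1 `Oc1ccc(-c2cc(-c3ccc(Cl)cc3)nc(-c3cccnc3)c2)cc1` gives 27500 nM in an ADME assay on HEK293 cells (Homo sapiens) for cytotoxicity, read by CCK-8 assay and cell counting, with a stated time of 2 days; on this read-out lower numbers stand for stronger inhibition and higher numbers for weaker inhibition; compound 3 `Oc1ccc(-c2cc(-c3cccnc3)nc(-c3cccc(Cl)c3)c2)cc1` gives 25700 nM; compound 2 `Oc1cccc(-c2cc(-c3ccc(Cl)cc3)nc(-c3ccsc3)c2)c1` gives 11200 nM, the lowest of the three. From compound 1 to compound 3 the change is 3-chlorophenyl in place of 4-chlorophenyl on an aromatic carbon, and the step is a 1.1-fold lower number from compound 1 to compound 3 (0.03 log units; within the scatter). The difference between the cores of compound 1 and compound 2 is not broken down here.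

Compound 4 `Oc1cccc(-c2cc(-c3ccsc3)nc(-c3cccc(Cl)c3)c2)c1` is not yet measured. For the measured compounds named here, it differs from compound 2 by 3-chlorophenyl in place of 4-chlorophenyl on an aromatic carbon, the same kind of change as the one from compound 1 to compound 3, though the surroundings differ: in compound 2 the place is meta to a 3-hydroxyphenyl group and meta to a thiophen-3-yl group, whereas in compound 1 it is meta to a 4-hydroxyphenyl group and meta to a pyridin-3-yl group. Because the earlier step of a 1.1-fold lower number from compound 1 to compound 3 (0.03 log units; within the scatter) stayed within the scatter, the expected step from compound 2 to compound 4 in this assay is a 1.1-fold lower number from compound 2 to compound 4 (0.03 log units; within the scatter). Compound 4 is therefore estimated at 10500 nM, between 5000 nM and 22000 nM.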

Compound 4, half-maximal inhibitory concentration: 3180 nM
Compound 4: the middle estimate sits 3.3-fold (0.52 log units) above what was measured; the measured number lies below the stated range.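

In this assay, 3-chlorophenyl in place of 4-chlorophenyl gives a 3.5-fold lower number from compound 2 to compound 4 (0.55 log units; beyond the scatter), so the same swap does not have the same size on both cores: the same change on two cores in this assay, a 1.1-fold lower number (0.03 log units; within the scatter) from compound 1 to compound 3 and a 3.5-fold lower number (0.55 log units; beyond the scatter) from compound 2 to compound 4, 3.3-fold (0.52 log units) apart, beyond the scatter of two such steps A step read on one core therefore cannot simply be copied to the other in this series, even though the group that leaves and the group that enters are the same in both pairs. This does not show what sets the two steps apart, and two pairs of compounds are too few to give a rule for other cores.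

On these data alone, the cores of compound 1 and compound 2 differ both in the hydroxyphenyl group and in the third ring, so it stays open whether the 3-hydroxyphenyl group, the thiophen-3-yl group or the two together go with the larger step. Also open, as far as these compounds go, is how the numbers would run with an amine or a carboxylic acid in place of the chlorine on either core.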